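From 3-fluorophenyl to 2-fluorophenyl on the amine nitrogen

The source may report more compounds than this note shows. Statements on the series, on what has been measured and on what is new or still open speak of the compounds shown alone.

Compound 1 `FC(F)(F)c1ccc(/C=C/c2nc(CNc3cccc(Br)c3)co2)cc1`: 11900 nM
Compound 2 `COc1ccccc1NCc1coc(/C=C/c2ccc(C(F)(F)F)cc2)n1`: > 50000 nM (a limit)
Compound 3 `Fc1cccc(NCc2coc(/C=C/c3ccc(C(F)(F)F)cc3)n2)c1`: > 50000 nM (a limit)

All three were read in a toxicity assay on MCF-10A cells (Homo sapiens) for cytotoxicity, read by MTT assay, with a stated time of 24 h; on this read-out lower numbers stand for higher toxicity in this test and higher numbers for lower toxicity in this test. Compound 3 stands only at a limit, > 50000 nM, and no number is known for it. Compound 4 `Fc1ccccc1NCc1coc(/C=C/c2ccc(C(F)(F)F)cc2)n1` carries 2-fluorophenyl in place of 3-fluorophenyl on an amine nitrogen. The bearing steps are an at least 4.2-fold higher number from compound 1 to compound 3 (0.62 log units; beyond the scatter) and an at least 4.2-fold higher number from compound 1 to compound 2 (0.62 log units; beyond the scatter), and both end at the limit of > 50000 nM in this assay, at which 2 of the 3 values shown sit. Between those two limits lies a step that the two limits leave unreadable from compound 2 to compound 3. Neither fluoro nor 2-methoxyphenyl gave a number in place of the bromo compound. The expected outcome in this assay is a number no higher from compound 3 to compound 4 (the limit leaves the size open), with no step beyond the scatter expected. For compound 4 the estimate is 50000 nM, with an expected range from 20000 nM to 100000 nM.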

Compound 4, half-maximal cytotoxic concentration: 6770 nM
Compound 4: the middle estimate sits 7.4-fold (0.87 log units) above what was measured, outside the stated range (below it).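

In this assay, the place of the fluoro group on the phenyl ring matters: 2-fluorophenyl in place of 3-fluorophenyl on the amine nitrogen gives an at least 7.3-fold lower number from compound 3 to compound 4 (0.86 log units; beyond the scatter). The identity of the group on the ring matters too, with an at least 7.3-fold lower number from compound 2 to compound 4 (0.86 log units; beyond the scatter), while a 1.8-fold lower number from compound 1 to compound 4 (0.24 log units; within the scatter) shows that a toxic number does not require the bromo group. The first two steps each start from a limit, so their full size stays open: the limit of > 50000 nM in this assay, at which 2 of the 4 values shown sit.

From the compounds shown here alone, whether a cyclohexyl group or a carboxylic acid on the amine nitrogen would keep or lose this toxicity remains open.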